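The source may hold more compounds than are shown below. What is called first, only, known or untested is meant among the compounds shown, and "the series" means these compounds.

The measured compounds:

Compound 1 `COc1ccc2c(OCc3nnc4sc(-c5ccc[nH]5)nn34)ccnc2c1` — 313 nM
Compound 2 `COc1ccc2c(OCc3nnc4sc(-c5cc6ccccc6n5C)nn34)ccnc2c1` — 149 nM
Compound 3 `COc1ccc2c(OCc3nnc4sc(-c5cc6cc(F)ccc6[nH]5)nn34)ccnc2c1` — "not determined" (no result reported)

In a functional assay on EBC-1 cells (Homo sapiens) for antiproliferative activity, with a stated time of 72 h (a higher number here means a weaker inhibitor, a lower number a stronger inhibitor), compound 1 gives 313 nM and compound 2 gives 149 nM. For compound 3 the result is "not determined" (no result reported), so it adds no number. For the measured compounds named here, the single measured step is a 2.1-fold lower number from compound 1 to compound 2 (0.32 log units; beyond the scatter), and on it compound 2 stands with the lower of the two numbers.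

Compound 4 `COc1ccc(-c2nn3c(COc4ccnc5cc(OC)ccc45)nnc3s2)cc1` follows from compound 2 by one change: 4-methoxyphenyl in place of 1-methyl-1H-indol-2-yl on an aromatic carbon. Going by the values given here, no measured step covers this exchange. Among the compounds with values here, the only step in hand swapped one five-membered-ring group for another at this position and moved the number modestly; the incoming 4-methoxyphenyl shares with the leaving group one six-membered aromatic ring of carbon only and one hydrogen-bond acceptor, but the five-membered ring is gone. The account therefore expects for compound 4 at most a modest shift in this assay, more likely toward a higher number than a lower one, and possibly none beyond the scatter. The estimated step is a 1.7-fold higher number from compound 2 to compound 4 (0.22 log units; within the scatter). Compound 4 is estimated at 250 nM, in the range 80 nM to 800 nM.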

Compound 4, half-maximal inhibitory concentration: 161 nM
Estimate against measurement, compound 4: 1.6-fold (0.19 log units) above; the measured number falls inside the stated range.
By their numbers in this assay, from the lowest: compounds 2, 4 and 1 (each within the scatter of the next, the first and the last beyond it).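

In this assay there is a 1.1-fold higher number from compound 2 to compound 4 (0.03 log units; within the scatter) when 4-methoxyphenyl replaces 1-methyl-1H-indol-2-yl, so at this aromatic carbon, next to the ring nitrogen and next to the ring sulfur, a group without a five-membered aromatic ring gives a number that cannot be told apart from that of compound 2. The second new step, a 1.9-fold lower number from compound 1 to compound 4 (0.29 log units; within the scatter), is also within the scatter, which leaves compound 4 level with both compound 1 and compound 2, even though those two differ beyond it. No evidence is at hand that bears on this result.

Going by these compounds, all the groups with a number at this carbon carry an aromatic ring, so what an amine or a carboxylic acid would do here remains open. Also open, on these data alone, is whether a plain phenyl would match 4-methoxyphenyl.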